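Hydroxy in Place of Methyl on the Carbonyl Carbon

The compounds below may be only part of what the source reports. "The series", "measured", "known", "first", "only" and "open" are said of these compounds alone.

Measured in an assay on isolated protein (strain Sprague-Dawley) for inhibition of Amine oxidase [flavin-containing] A (Rattus norvegicus), read by spectrophotometry, with a stated time of 5 min, tested at 10 uM; on this read-out lower numbers stand for less inhibition and higher numbers for more inhibition at the one concentration tested (going by the name of the read-out):
Compound 1 `CCOC(=O)COc1cc(=O)oc2cc(OCc3cccc(Cl)c3)ccc12`: 0%
Compound 2 `CCOC(=O)Nc1cc(=O)oc2cc(OCc3cccc(Cl)c3)ccc12`: 21%
Compound 3 `CC(=O)c1cc(=O)oc2cc(OCc3cccc(Cl)c3)ccc12`: 0%

Compound 3 stands level with compound 1 at the digits shown, the two together lowest of the three; the step of no change at the digits printed from compound 1 to compound 3 (within the scatter) is within the scatter, while the step of a number 21 percentage points lower from compound 2 to compound 3 (beyond the scatter) lies beyond it. Compound 4 `O=C(O)c1cc(=O)oc2cc(OCc3cccc(Cl)c3)ccc12` differs from compound 3 by hydroxy in place of methyl on a carbonyl carbon. Neither measured step touches the carbonyl carbon itself; both exchange the whole group on the aromatic carbon, so they bear only loosely on this change, and only compound 2 rose above the floor. For compound 4 a step of a number 5 percentage points higher from compound 3 to compound 4 (within the scatter) is expected, not beyond the scatter. Compound 4 is estimated at 5%, with a range from 0% to 20%.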

Compound 4, a percentage reported as inhibition, at one concentration (the size of the read-out at that concentration, not a potency): 0%
The estimate for compound 4 lay 5 percentage points above the measured number; low and high end bracket the measured number.
By their numbers in this assay, from the lowest: compounds 1, 3 and 4 (each within the scatter of the next); then compound 2.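

In this assay the change from methyl to hydroxy on the carbonyl carbon gives no change at the digits printed from compound 3 to compound 4 (within the scatter), so acetyl and carboxy are not told apart at this position. The carboxy compound also shows no change at the digits printed from compound 1 to compound 4 (within the scatter) and a number 21 percentage points lower from compound 2 to compound 4 (beyond the scatter), which leaves the (ethoxycarbonyl)amino group of compound 2 alone above the other three. Nothing available explains these results.

Still open, from the compounds shown here alone, is whether a plain amine or a primary amide on this aromatic carbon would match compound 2. So is whether a longer carbamate chain would exceed it.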